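A Bulkier Aryl Group on the Ring Nitrogen

The source may report more compounds than this note shows. Statements on the series, on what has been measured and on what is new or still open speak of the compounds shown alone.

The compounds share one core and differ in the aryl group attached to an aromatic nitrogen of a five-membered aromatic ring with 3 nitrogen. Compound 1 `N#CC1=C(N)Oc2c(c3nc4ccccc4nc3c3ccccc23)C12C(=O)N(Cc1cnnn1-c1cccc(Br)c1)c1ccccc12` carries a 3-bromophenyl there, compound 2 `COc1ccc(-n2nncc2CN2C(=O)C3(C(C#N)=C(N)Oc4c3c3nc5ccccc5nc3c3ccccc43)c3ccccc32)cc1` a 4-methoxyphenyl, and compound 3 `N#CC1=C(N)Oc2c(N)cc3nc4ccccc4nc3c2C12C(=O)N(Cc1cnnn1-c1ccc(F)cc1)c1ccccc12` a 4-fluorophenyl together with an added amine on the core.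

In a functional assay on HCT-116 cells (Homo sapiens) for antiproliferative activity, read by MTT assay, with a stated time of 48 h (on this read-out higher numbers stand for weaker inhibition and lower numbers for stronger inhibition), compound 1 gives only a limit, > 50000 nM. Compound 2 likewise reaches only the limit, > 50000 nM. Compound 3 also stops at the limit, > 50000 nM. Going by the values given here, because all three values sit at the limit of > 50000 nM in this assay, at which 3 of the 3 values shown sit, the single step between measured neighbours, a step that the two limits leave unreadable from compound 1 to compound 2, has no readable size, and compound 3 stands on the same limit as its two companions, with no number to set it apart.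

Compound 4 `CCc1cccc(C)c1-n1nncc1CN1C(=O)C2(C(C#N)=C(N)Oc3c(N)cc4nc5ccccc5nc4c32)c2ccccc21` differs from compound 3 by 2-ethyl-6-methylphenyl in place of 4-fluorophenyl on an aromatic nitrogen. Among the compounds with values here, no measured step bears directly on this change, and the one step that exists is unreadable, so no shift beyond the scatter can be foreseen in either direction. The expected step is a step that the limit leaves unreadable from compound 3 to compound 4. Compound 4 is estimated at 80000 nM, with a range from 40000 nM to 200000 nM, most likely again reported only as a limit.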

Compound 4, half-maximal inhibitory concentration: > 50000 nM
Compound 4 was reported as a limit; the forecaster's own chance of this, stated with the estimate: 85%; the middle value is on the limit's open side.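

No step can be read from compound 3 to compound 4, because both stop at a limit rather than a number: the limit of > 50000 nM in this assay, at which 4 of the 4 values shown sit.

The compounds shown leave open how strongly any of the four acts on these cells, and whether swapping the aryl group or adding the amine on the core changes that activity at all.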